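This account rests on a few compounds, and the source may have more. Where it says the series, first, only, none or still open, it means among the compounds named here.

Of the compounds shown here, two built on the same core have been tested in a functional assay on MCF7 cells (Homo sapiens) for antiproliferative activity, read by CCK-8 assay, with a stated time of 48 h; on this read-out lower numbers stand for stronger inhibition and higher numbers for weaker inhibition. Compound 1, `O=c1c2ccccc2[se]n1-c1nnc(-c2ccc(Br)cc2)s1`, gives 43300 nM. Compound 2, `COc1cc(-c2nnc(-n3[se]c4ccccc4c3=O)s2)cc(OC)c1OC`, gives 3440 nM. Of these two numbers compound 1 has the higher one, so it is the weaker inhibitor; the gap to compound 2 lies beyond the usual scatter of this kind of measurement.

Compound 3, `COc1ccc(-c2nnc(-n3[se]c4ccccc4c3=O)s2)cc1`, has not yet been measured. It differs from compound 1 in one place: methoxy in place of bromo on an aromatic carbon. Compound 2 carries three methoxy groups on its outer ring and gives the lower number, whereas compound 1 carries only a bromo there and gives the higher number. No single change of this exact kind has been measured, so the step can only be expected, not computed. A moderate drop in the number is expected, with compound 3 estimated at 15000 nM, somewhere between 5000 nM and 45000 nM, which would mean an expected step of a 2.9-fold lower number from compound 1 to compound 3 (0.46 log units; beyond the scatter).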

Compound 3, half-maximal inhibitory concentration: 10000 nM
Estimate against measurement, compound 3: 1.5-fold (0.18 log units) above; low and high end bracket the measured number.
By their numbers in this assay, from the lowest: compound 2; then compound 3; then compound 1.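

In this assay, replacing the bromo with methoxy on the six-membered aromatic ring gives a 4.3-fold lower number from compound 1 to compound 3 (0.64 log units; beyond the scatter) with nothing else altered. Within the data shown here, the earlier pair differed in more than one place, so this is the first direct sign that the group at this position alone can shift the number beyond the usual scatter, and that methoxy gives the lower number here. Nothing measured here explains the shift.

Going by these compounds, whether an amine, a carboxylic acid or a longer chain at this same place would lower the number further or raise it remains open. Also open, on these data alone, is what a plain hydrogen there would give, which would show how bromo and methoxy each compare with having no group at all.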